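Methoxy for Methyl on the Fused Ring of Compound 2

The compounds below may be only part of what the source reports. "The series", "measured", "known", "first", "only" and "open" are said of these compounds alone.

Compound 1, `Cc1cnc(Nc2ccc(Cl)cc2)nc1Nc1nc2ccccc2s1`: > 50000 nM
Compound 2, `Cc1ccc2nc(Nc3ccnc(Nc4ccc(S(C)(=O)=O)cc4)n3)sc2c1`: > 50000 nM
Compound 3, `NS(=O)(=O)c1ccc(Nc2nccc(Nc3nc4ccccc4s3)n2)cc1`: 3100 nM

All three were tested in a functional assay on PC-3 cells (Homo sapiens) for antiproliferative activity, read by MTT assay, with a stated time of 48 h; on this read-out higher numbers stand for weaker inhibition and lower numbers for stronger inhibition. The value given for compound 1 is a limit of the assay, not a measured number. The same holds for compound 2, whose entry of > 50000 nM is also a limit. Compound 3 is the only one of the three with a measured number, 3100 nM in this assay. Compound 2 thus stands at the limit of > 50000 nM in this assay, at which 2 of the 3 values shown sit, and nothing more precise is known about where it would fall if a number could be reached.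

Compound 4, `COc1ccc2nc(Nc3ccnc(Nc4ccc(S(C)(=O)=O)cc4)n3)sc2c1`, differs from compound 2 in one place: methoxy in place of methyl on an aromatic carbon. Within the data shown here, no pair of measured compounds differs in a single place, so there is no measured step of this kind to lean on. Compound 3 does show that a measurable number is possible for this kind of structure, but it differs from compound 2 in more than one place, so only its value and that of compound 2 can be set side by side.

The expected step is an at least 1.2-fold lower number from compound 2 to compound 4 (0.09 log units; that floor lies within the scatter), modest at best and possibly none beyond the scatter. Compound 4 is estimated at 40000 nM in this assay. For compound 4 the estimated range runs from an expected lower end of 6000 nM to an expected upper end of 100000 nM, with a real chance that only a limit is reported again.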

Compound 4, half-maximal inhibitory concentration: 2700 nM
The estimate for compound 4 lay 15-fold (1.17 log units) above the measured number; the measured number lies below the stated range.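

In this assay, methoxy in place of methyl on this aromatic carbon gives an at least 18-fold lower number from compound 2 to compound 4 (1.26 log units; beyond the scatter), so what sits at this position of the fused ring clearly matters for the read-out. Among these compounds, until now no two measured compounds differed in a single place, and this pair is the first direct sign that one small change here can turn a compound known only by a limit into one with a measured number. The size of the step is only a floor, because compound 2 has a limit rather than a number: the limit of > 50000 nM in this assay, at which 2 of the 4 values shown sit.

On these data alone, a single pair cannot say which feature of the methoxy group matters, and how a hydroxyl, an ethoxy group, an amine or a chlorine on the same carbon would compare remains open. Among the compounds shown here, it also remains open whether methoxy at this position would lower the number to a similar degree on a compound with a different group on the far aromatic ring, such as the one carried by compound 3.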